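The compounds below may be only part of what the source reports. "The series", "measured", "known", "first", "only" and "open" are said of these compounds alone.

In an ADME assay on MT4 cells (Homo sapiens) for cytotoxicity, read by spectrophotometry, with a stated time of 5 days (on this read-out lower numbers stand for higher toxicity in this test and higher numbers for lower toxicity in this test), compound 1 `CONC(=S)N/N=C1\C(=O)N(CN(C)C)c2ccc(F)cc21` gives 560000 nM and compound 2 `CONC(=S)N/N=C1\C(=O)N(CN(C)C)c2ccc(C)cc21` gives 622000 nM in the same test. Compound 3 `CN(C)CN1C(=O)/C(=N\NC(=S)NO)c2cc(Cl)ccc21` gives 610000 nM and so lies within the scatter of both. Compound 4 `CONC(=S)N/N=C1\C(=O)N(CN(C)C)c2ccc(Cl)cc21` departs from compound 3 by methyl in place of hydrogen on an oxygen, hydroxyamino to methoxyamino. Among the measured compounds shown here, no measured step touches that oxygen. The only one (a 1.1-fold higher number from compound 1 to compound 2 (0.05 log units; within the scatter)) is methyl in place of fluoro on an aromatic carbon and stays within the scatter, while compound 1 and compound 2 already carry methoxyamino and sit level with compound 3. No step beyond the scatter is therefore expected, and the estimated step (a 1.0-fold lower number from compound 3 to compound 4 (0.01 log units; within the scatter)) is small. Compound 4 is expected at 590000 nM (estimated range 400000 nM to 850000 nM).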

Compound 4, half-maximal cytotoxic concentration: 552000 nM
Estimate against measurement, compound 4: 1.1-fold (0.03 log units) above, and the stated range covers the measured number.
By their numbers in this assay, from the lowest: compounds 4, 1, 3 and 2 (each within the scatter of the next).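

In this assay, among the compounds shown here, methyl in place of hydrogen on an oxygen, hydroxyamino to methoxyamino, gives a 1.1-fold lower number from compound 3 to compound 4 (0.04 log units; within the scatter) and so stays within the scatter, a change that no earlier step had covered. Chloro in place of methyl on an aromatic carbon gives a 1.1-fold lower number from compound 2 to compound 4 (0.05 log units; within the scatter) and chloro in place of fluoro there gives a 1.0-fold lower number from compound 1 to compound 4 (0.01 log units; within the scatter), so these changes at that carbon also leave the numbers level. No evidence is available that bears on this result. From the compounds shown here alone, whether an ethoxy or benzyloxy group on that nitrogen, or an amine or a carboxylic acid on that aromatic carbon, would move the number beyond the scatter remains open.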